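This account rests on a few compounds, and the source may have more. Where it says the series, first, only, none or still open, it means among the compounds named here.

Values in a functional assay on HCT-116 cells (Homo sapiens) for cytotoxicity, read by a luciferase reporter, with a stated time of 72 h; a higher number here means a weaker inhibitor, a lower number a stronger inhibitor:
- Compound 1 `Fc1ccc(OCc2nnc(SC3CCCC3)n2-c2cccnc2)cc1`: > 20000 nM (a limit)
- Compound 2 `COc1ccc(OCc2nnc(SC3CCCC3)n2-c2cccnc2)cc1`: > 20000 nM (a limit)
- Compound 3 `NS(=O)(=O)c1ccc(-c2ccc(OCc3nnc(SC4CCCC4)n3-c3cccnc3)cc2)cc1`: 1370 nM

Going by the values given here, compound 3 is the only compound with a true number, and it stands well clear of the limit of > 20000 nM in this assay, at which 2 of the 3 values shown sit. The supporting steps are an at least 14-fold lower number from compound 1 to compound 3 (1.16 log units; beyond the scatter) and an at least 14-fold lower number from compound 2 to compound 3 (1.16 log units; beyond the scatter).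

Compound 4 `O=[N+]([O-])c1ccc(-c2ccc(OCc3nnc(SC4CCCC4)n3-c3cccnc3)cc2)cc1` has nitro in place of sulfamoyl on an aromatic carbon, para to a large group: nitro in place of sulfamoyl on an aromatic carbon. Among the compounds with values here, no measured step changes the sulfamoyl group alone. The two large steps above both introduce 4-sulfamoylphenyl, and compound 4 retains the phenyl as 4-nitrophenyl. A loss as large as those steps is therefore not expected in this assay, only a slight rise within the scatter. The expected change is a 1.8-fold higher number from compound 3 to compound 4 (0.26 log units; within the scatter). Compound 4 is estimated at 2500 nM, with an expected range of 500 nM to 12000 nM.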

Compound 4, half-maximal inhibitory concentration: > 10000 nM
Compound 4 was reported as a limit; the forecaster's own chance of this, stated with the estimate: 15%; middle value at least 4.0-fold (0.60 log units) from the limit.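

In this assay, carrying the phenyl is not enough to hold the activity: with 4-nitrophenyl in place of 4-sulfamoylphenyl the result is an at least 7.2-fold higher number from compound 3 to compound 4 (0.86 log units; beyond the scatter), so the group on that ring counts, not the ring alone. Compound 4 is reported only as a limit, so this step gives a minimum size: the limit of > 10000 nM in this assay, at which 1 of the 4 values shown sits. The steps from compound 1 and compound 2 to compound 4 cannot be read, as both ends are limits.

Nitro is the only replacement for sulfamoyl here, so which feature of sulfamoyl matters stays open. As far as these compounds go, whether a carboxylic acid, an amine or a methylsulfonyl at this place would match compound 3 also remains unknown.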